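Swapping bromo for fluoro on the cinnamamide ring

A few compounds are considered here, and "the series" means these few. Any claim that something is new, unique, unknown or untested is made for them only; others in the source may bear on it.

Measured so far:
- compound 1, `Cc1ccc(-c2cc(NC(=O)/C=C/c3ccc(Br)cc3)n[nH]2)cc1`, 1570 nM
- compound 2, `O=C(/C=C/c1ccc(Br)cc1)Nc1cc(-c2ccc(Br)cc2)[nH]n1`, 1280 nM
- compound 3, `O=C(/C=C/c1ccc(Br)cc1)Nc1cc(-c2ccccc2)[nH]n1`, 1380 nM

All three values come from a functional assay on B16-F10 cells (Mus musculus) for antiproliferative activity, read by MTT assay, with a stated time of 48 h; on this read-out lower numbers stand for stronger inhibition and higher numbers for weaker inhibition. Compound 1 gives the highest of the three numbers, yet its separation from the others is small: the step of a 1.2-fold lower number from compound 1 to compound 2 (0.09 log units; within the scatter) and the step of a 1.1-fold lower number from compound 1 to compound 3 (0.06 log units; within the scatter) both fall within the scatter, as does a 1.1-fold higher number from compound 2 to compound 3 (0.03 log units; within the scatter). These three compounds are therefore best read as equally potent on this assay.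

Compound 4, `Cc1ccc(-c2cc(NC(=O)/C=C/c3ccc(F)cc3)n[nH]2)cc1`, has not yet been measured. Relative to compound 1 it differs by fluoro in place of bromo on an aromatic carbon. For the measured compounds named here, none of the measured steps touches this position; they all alter the other aromatic ring, where a methyl, a bromo and a hydrogen gave indistinguishable results. Going by the values given here, no direct precedent for the bromo-to-fluoro exchange therefore exists here, and a halogen swap of this kind is a small structural change. On that basis compound 4 is expected to stay close to compound 1, with a step of a 1.0-fold lower number from compound 1 to compound 4 (0.02 log units; within the scatter) that is not expected to exceed the scatter. Compound 4 is estimated at 1500 nM, within a range from 700 nM to 3200 nM.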

Compound 4, half-maximal inhibitory concentration: 1430 nM
Compound 4: the middle estimate sits 1.0-fold (0.02 log units) above what was measured; low and high end bracket the measured number.
By their numbers in this assay, from the lowest: compounds 2, 3, 4 and 1 (each within the scatter of the next).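

For the compounds shown here, until now, every step changed the other aromatic ring, so this is the first reading of a change on the ring of the cinnamamide, and in this assay replacing 4-bromophenyl with 4-fluorophenyl gives a 1.1-fold lower number from compound 1 to compound 4 (0.04 log units; within the scatter). At this place, para to a large group, bromo can therefore give way to fluoro with no readable change in antiproliferative activity, so this activity does not depend on bromo specifically, and compound 1 and compound 4 are best treated as equally potent. The compounds shown offer no independent measurement that could explain why these two halogens read alike.

As far as these compounds go, both groups compared at this place are halogens, so it remains open whether the position would respond to a plain hydrogen, or to something quite different such as an amine, a carboxylic acid or a longer alkyl chain. Going by these compounds alone, it is also open whether the exchange of bromo for fluoro would read the same when the other aromatic ring carries bromo or hydrogen instead of methyl, as the single step here has methyl on that ring.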